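Triazole acetamides: swapping chloro for methoxy

The source may report more compounds than this note shows. Statements on the series, on what has been measured and on what is new or still open speak of the compounds shown alone.

Measured so far in a functional assay on BMDM cells (Mus musculus, strain C57BL/6) for inhibition, with a stated time of 2 days; a higher number here means a weaker inhibitor, a lower number a stronger inhibitor:
compound 1 `Nc1cccc(-c2cn(CC(=O)Nc3nccs3)nn2)c1` gives 1270 nM;
compound 2 `Cc1cc(NC(=O)Cn2cc(-c3ccc(Cl)cc3)nn2)no1` gives 1910 nM;
compound 3 `CCOC(=O)c1sc(NC(=O)Cn2cc(-c3ccc(OC)cc3)nn2)nc1C` gives 2330 nM.

All three share a common core and differ in the aryl group and the amide partner. In this assay compound 2 stands second highest of the three numbers, its nearest neighbour being compound 3 and its furthest compound 1, and both of those gaps fall within the usual scatter of repeated measurements, so nothing separates the three with confidence.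

The untested compound 4 `COc1ccc(-c2cn(CC(=O)Nc3cc(C)on3)nn2)cc1` keeps the amide partner of compound 2 and changes only the aryl substituent: methoxy in place of chloro on an aromatic carbon. For the measured compounds named here, no pair of measured compounds differing in a single place exists here, so the size of this step cannot be read from the data. Compound 3, which also carries a methoxy group, gives a value close to that of compound 2, which offers no sign of a large shift.

Compound 4 is therefore expected to land within the scatter of compound 2, giving an estimated 2200 nM (range 1000 nM to 5000 nM), an expected step of a 1.2-fold higher number from compound 2 to compound 4 (0.06 log units; within the scatter).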

Compound 4, half-maximal inhibitory concentration: > 30000 nM
Compound 4 gave a limit, no number (the forecaster's own chance of this, stated with the estimate: 5%); middle value at least 13-fold (1.13 log units) away from the limit.
By their numbers in this assay, from the lowest: compounds 1, 2 and 3 (each within the scatter of the next). At a limit, above all of these: compound 4.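

Read in this assay, methoxy in place of chloro gives the first step in this series that differs in one place, and it is large: an at least 15-fold higher number from compound 2 to compound 4 (1.19 log units; beyond the scatter). Compound 4 stands at a limit of the assay, not at a number: the limit of > 30000 nM in this assay, at which 1 of the 4 values shown sits. For the compounds shown here, the three earlier values lay within the scatter of one another and included no pair differing in one place, so they could not show what this step shows: with the amide partner of compound 2, the group on this aromatic carbon, para to a large group, can matter a great deal in this assay.

Because compound 4 is a limit, the true size of the step remains unknown, and the compounds shown do not tell whether the change would have a similar effect with another amide partner. They also leave open where a fluoro, a methyl or a hydroxyl on the same carbon would fall, and so whether the result reflects the loss of chloro or the arrival of methoxy.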